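A few compounds are considered here, and "the series" means these few. Any claim that something is new, unique, unknown or untested is made for them only; others in the source may bear on it.

The measured compounds:

- compound 1, `N#Cc1ncn(-c2ccc(F)cc2)c1/N=C/c1ccc(O)cc1`: 16300 nM
- compound 2, `COc1ccc(/C=N/c2c(C#N)ncn2-c2ccc(F)cc2)cc1`: 17100 nM
- compound 3, `COc1ccc(/C=N/c2c(C#N)ncn2Cc2ccc(F)cc2)cc1O`: 1320 nM

All three compounds were tested in a functional assay on A549 cells (Homo sapiens) for antiproliferative activity, read by MTT assay, with a stated time of 48 h; on this read-out lower numbers stand for stronger inhibition and higher numbers for weaker inhibition. Compound 1 and compound 2 differ in one place only: methyl in place of hydrogen on an oxygen on an aromatic ring. This change produced a 1.0-fold higher number from compound 1 to compound 2 (0.02 log units; within the scatter), so the two compounds cannot be told apart on this read-out. Compound 3 is built on a different core, and the difference between the two cores is not broken down here. In this assay compound 3 gives 1320 nM, which is lower than the numbers of compound 1 and compound 2 by more than the usual scatter, making it the most potent of the three measured compounds.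

Compound 4, `COc1ccc(/C=N/c2c(C#N)ncn2Cc2ccc(F)cc2)cc1OC`, has not yet been measured. It differs from compound 3 in the following way: methyl in place of hydrogen on an oxygen on an aromatic ring. Going by the values given here, this is the same change that separates compound 1 from compound 2, made at a place described in the same words, so the earlier pair is the only guide available. The step is expected to be about a 1.1-fold higher number from compound 3 to compound 4 (0.06 log units; within the scatter), which would again fall within the scatter. Going by these compounds, this expectation rests on the matching change between compound 1 and compound 2, which gave a 1.0-fold higher number from compound 1 to compound 2 (0.02 log units; within the scatter); whether the same holds on the core of compound 3 is untested. Compound 4 is therefore estimated at 1500 nM in this assay. The estimate for compound 4 is expected to lie between 500 nM and 4500 nM.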

Compound 4, half-maximal inhibitory concentration: 9130 nM
Beside the measured number, compound 4's estimate is 6.1-fold (0.78 log units) below it; the whole stated range lies below it.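

In this assay, replacing hydroxy with methoxy gave a 6.9-fold higher number from compound 3 to compound 4 (0.84 log units; beyond the scatter), so on the core of compound 3 this small change weakens the measured activity by more than the usual scatter. Set beside the earlier pair, the same change does not carry the same size of step from one core to the other: the same change on two cores in this assay, a 1.0-fold higher number (0.02 log units; within the scatter) from compound 1 to compound 2 and a 6.9-fold higher number (0.84 log units; beyond the scatter) from compound 3 to compound 4, 6.6-fold (0.82 log units) apart, beyond the scatter of two such steps. This shows that a step measured on one core in this series cannot simply be transferred to another, but it does not show which difference between the two cores is responsible, and two pairs give no rule for what the change would do on any further core.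

The compounds shown leave open how the core of compound 3 responds to other groups on that oxygen, such as an ethyl group or a longer chain, and whether the size of the step rises with the size of the group. They also leave open whether an amine in place of the hydroxy would keep the activity of compound 3 or would move it towards that of compound 4.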